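The source may hold more compounds than are shown below. What is called first, only, known or untested is meant among the compounds shown, and "the series" means these compounds.

Measured in a functional assay on PC-3 cells (Homo sapiens) for antiproliferative activity, read by MTT assay, with a stated time of 48 h; a higher number here means a weaker inhibitor, a lower number a stronger inhibitor:
Compound 1 `CCn1c(C(=O)NCC#N)ccc1C(CC)(CC)c1ccc(OCCC(O)(CC)CC)c(C)c1`: 17800 nM
Compound 2 `CCn1c(C(=O)N(CCC#N)CCC#N)ccc1C(CC)(CC)c1ccc(OCCC(O)(CC)CC)c(C)c1`: > 50000 nM, a limit of the assay
Compound 3 `C=CCN(C)C(=O)c1ccc(C(CC)(CC)c2ccc(OCCC(O)(CC)CC)c(C)c2)n1CC`: 12800 nM

Compound 3 stands level with compound 1 in this assay, since a 1.4-fold lower number from compound 1 to compound 3 (0.14 log units; within the scatter). It lies clearly apart from compound 2, with an at least 3.9-fold lower number from compound 2 to compound 3 (0.59 log units; beyond the scatter), although that comparison rests on a limit and not on a number.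

The next compound, compound 4 `C#CC(C)OC(=O)c1ccc(C(CC)(CC)c2ccc(OCCC(O)(CC)CC)c(C)c2)n1CC`, keeps the core of compound 3 and changes one group: (1-methylprop-2-yn-1-yl)oxy in place of allyl(methyl)amino on a carbonyl carbon. In words, (1-methylprop-2-yn-1-yl)oxy replaces allyl(methyl)amino on a carbonyl carbon.

For the measured compounds named here, no measured compound carries this new group, so the evidence is indirect. Going by the values given here, the closest precedent is the exchange of one small group for another at the same place, a 1.4-fold lower number from compound 1 to compound 3 (0.14 log units; within the scatter), which stayed within the scatter. The only clear rise came with the much larger group of compound 2, an at least 2.8-fold higher number from compound 1 to compound 2 (0.44 log units; beyond the scatter), and the entering group in compound 4 is no larger than the one it replaces. Going by these compounds, no step beyond the scatter is therefore expected, though the loss of the nitrogen remains untested in these data.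

The expected change is a 1.1-fold higher number from compound 3 to compound 4 (0.04 log units; within the scatter). For compound 4 the expected value is 14000 nM, with an estimated range from 6000 nM to 35000 nM.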

Compound 4, half-maximal inhibitory concentration: 14800 nM
For compound 4 the middle estimate is 1.1-fold (0.02 log units) below the measured one; measured number inside the range.
By their numbers in this assay, from the lowest: compounds 3, 4 and 1 (each within the scatter of the next). At a limit, above all of these: compound 2.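

Exchanging allyl(methyl)amino for (1-methylprop-2-yn-1-yl)oxy on a carbonyl carbon leaves the result in this assay within the scatter (a 1.2-fold higher number from compound 3 to compound 4 (0.06 log units; within the scatter)), so a nitrogen on this carbonyl carbon is not needed to hold this level of activity, as compounds 1 and 3, which both carry one there, could not show. The comparison with the group of compound 1 also stays within the scatter (a 1.2-fold lower number from compound 1 to compound 4 (0.08 log units; within the scatter)), which means that an amino group bearing a nitrile, an amino group bearing an allyl and a group joined through oxygen all sit level at this position. Compound 4 stands clearly apart from compound 2 (an at least 3.3-fold lower number from compound 2 to compound 4 (0.52 log units; beyond the scatter)), but that step rests on a value that is a limit and not a number: the limit of > 50000 nM in this assay, at which 1 of the 4 values shown sits.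

The exchange alters the linking atom and the triple bond together, so the compounds shown do not separate the part each plays, and a simple methoxy group would be needed to do so. Going by these compounds, how a carboxylic acid or a primary amide at this carbonyl carbon would compare also remains open.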